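The source may hold more compounds than are shown below. What is called first, only, known or untested is meant among the compounds shown, and "the series" means these compounds.

Compound 1 `Cc1nc(-c2ccccc2)sc1CN1C(=O)N(C)c2ccc(-c3c(C)noc3C)cc2C1c1ccccc1`: 35.1%
Compound 2 `Cc1noc(C)c1-c1ccc2c(c1)C(c1ccccc1)N(Cc1nnc(-c3ccccc3)s1)C(=O)N2C`: 35.7%
Compound 3 `Cc1noc(C)c1-c1ccc2c(c1)C(c1ccccc1)N(Cc1nc(-c3ccccc3)cs1)C(=O)N2C`: 29.1%

These three compounds share one core and were tested in a functional assay on MCF7 cells (Homo sapiens) for inhibition, read by MTT assay, with a stated time of 48 h, tested at 2 uM; on this read-out lower numbers stand for less inhibition and higher numbers for more inhibition at the one concentration tested (going by the name of the read-out). Compound 1 stands second of the three numbers, with a number 0.6 percentage points higher from compound 1 to compound 2 (within the scatter) and a number 6 percentage points lower from compound 1 to compound 3 (within the scatter), both within the scatter, so the three cannot be told apart. Compound 4 `Cc1nc(-c2ccc(F)cc2)sc1CN1C(=O)N(C)c2ccc(-c3c(C)noc3C)cc2C1c1ccccc1` differs from compound 1 by fluoro in place of hydrogen on an aromatic carbon. Among the compounds with values here, no measured step involves this kind of change: the three known steps, including a number 6.6 percentage points lower from compound 2 to compound 3 (within the scatter), all swap the ring on the saturated chain carbon bound to the amide-type nitrogen, and all stay within the scatter. With nothing pointing either way, the expected step is a number 0.1 percentage points lower from compound 1 to compound 4 (within the scatter), none beyond the scatter. In this assay compound 4 is therefore estimated to give 35%, from 22% to 48%.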

Compound 4, a percentage reported as inhibition, at one concentration (the size of the read-out at that concentration, not a potency): 33.4%
The estimate for compound 4 lay 1.6 percentage points above the measured number; low and high end bracket the measured number.
By their numbers in this assay, from the lowest: compounds 3, 4, 1 and 2 (each within the scatter of the next).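

Unlike the earlier steps, which swap the ring on the saturated chain carbon, this one alters the outer aromatic ring, turning phenyl into 4-fluorophenyl, and in this assay it gives a number 1.7 percentage points lower from compound 1 to compound 4 (within the scatter). At this place, then, fluoro and hydrogen cannot be told apart at the one concentration tested. No supporting data bear on this result.

As far as these compounds go, whether an amine, a carboxylic acid or a longer chain at this same place would also stay within the scatter remains open.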